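Indole methyl relocation in the SW480 series

This account rests on a few compounds, and the source may have more. Where it says the series, first, only, none or still open, it means among the compounds named here.

Among the compounds with values here, compound 1 `Cc1[nH]c2ccccc2c1C1=CCC(NCc2ccc(OCC(=O)NO)cc2F)CC1` stands as the only number in the set: in a functional assay on SW480 cells (Homo sapiens) for antiproliferative activity, with a stated time of 72 h (a higher number here means a weaker inhibitor, a lower number a stronger inhibitor), compound 1 gives 170 nM. Compound 2 `Cc1[nH]c2cccc(F)c2c1C1=CCC(NCc2ccc(OCC(=O)NO)cc2F)CC1` has no result in this assay, "nd" (no result reported). Compound 3 `Cc1ccc2[nH]cc(C3=CCC(NCc4ccc(OCC(=O)NO)cc4F)CC3)c2c1` keeps the same atoms, joined differently: 5-methyl-1H-indol-3-yl in place of 2-methyl-1H-indol-3-yl on a double-bonded ring carbon. Within the data shown here, no measured step of this kind exists here, so the direction is open; a step within or just beyond the usual scatter is expected, with a small loss in potency more likely than a gain, giving a 1.9-fold higher number from compound 1 to compound 3 (0.27 log units; within the scatter). Compound 3 is thus estimated at 320 nM, with a range from 110 nM to 950 nM.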

Compound 3, half-maximal inhibitory concentration: 2780 nM
Compound 3: the middle estimate sits 8.7-fold (0.94 log units) below what was measured; the measured number lies above the stated range.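

Moving the methyl turns out not to be a neutral change at this place: in this assay, 5-methyl-1H-indol-3-yl in place of 2-methyl-1H-indol-3-yl gives a 16-fold higher number from compound 1 to compound 3 (1.21 log units; beyond the scatter), beyond the scatter. The two groups match in every count, so the placement of the methyl alone separates compound 1 and compound 3. Nothing at hand accounts for the loss.

The compounds shown do not separate losing the 2-methyl from gaining the 5-methyl. As far as these compounds go, the unsubstituted 1H-indol-3-yl group and 2-ethyl-1H-indol-3-yl remain open comparisons.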